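A heteroaryl swap on a saturated ring carbon

The source may report more compounds than this note shows. Statements on the series, on what has been measured and on what is new or still open speak of the compounds shown alone.

Compound 1 `CCN(CC)S(=O)(=O)c1ccc(S(=O)(=O)N2CCC[C@@H](C(=O)NC3COC3)C2)cc1` reaches only the assay limit of > 10000 nM in a functional assay on MIA PaCa-2 cells (Homo sapiens) for inhibition, read by MTT assay, with a stated time of 3 days; a higher number here means a weaker inhibitor, a lower number a stronger inhibitor.
Compound 2 `CCN(CC)S(=O)(=O)c1ccc(S(=O)(=O)N2CCC[C@@H](c3nc(C)no3)C2)cc1` likewise reaches only the limit of > 10000 nM in this assay.

Compound 2 therefore stands at the limit of this assay, and nothing more than that limit is known for it. The step that the two limits leave unreadable from compound 1 to compound 2 is unreadable, since both ends are limits; indeed (the limit of > 10000 nM in this assay, at which 2 of the 2 values shown sit). Compound 3 `CCN(CC)S(=O)(=O)c1ccc(S(=O)(=O)N2CCC[C@@H](c3cc(C)no3)C2)cc1` differs from compound 2 in one place: 3-methyl-1,2-oxazol-5-yl in place of 3-methyl-1,2,4-oxadiazol-5-yl on a saturated ring carbon. Within the data shown here, no measured step bears on this change in a readable way, so no direction or size can be drawn from the numbers so far. With both measured compounds at the limit of this assay, compound 3 is expected to stay at or near that limit as well, with the step that the limit leaves unreadable from compound 2 to compound 3 expected to be small. Compound 3 is thus estimated at 15000 nM in this assay, within a range of 4000 nM to 60000 nM, most likely reported again as a limit.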

Compound 3, half-maximal inhibitory concentration: > 10000 nM
Compound 3 gave a limit, no number; the forecaster's own chance of this, stated with the estimate: 85%; the middle value is on the limit's open side.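

Among these compounds, compound 3 also gives only a limit, so no step among compound 1, compound 2 and compound 3 can be read in this assay: the limit of > 10000 nM in this assay, at which 3 of the 3 values shown sit.
The compounds shown leave open whether the group on the saturated ring carbon affects inhibition at all, and what true value each compound has.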